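The source may report more compounds than this note shows. Statements on the series, on what has been measured and on what is new or still open speak of the compounds shown alone.

Measured in a functional assay on SK-OV-3 cells (Homo sapiens) for cytotoxicity, read by MTT assay, with a stated time of 2 days; on this read-out lower numbers stand for stronger inhibition and higher numbers for weaker inhibition:

compound 1 `Cc1ccc(CO/N=C2/C(c3c[nH]c4ccccc34)=Nc3ccccc32)cc1` gives 32400 nM
compound 2 `Fc1ccc(CO/N=C2/C(c3c[nH]c4ccccc34)=Nc3ccccc32)cc1` gives 29000 nM
compound 3 `FC(F)(F)c1ccc(CO/N=C2/C(c3c[nH]c4ccccc34)=Nc3ccccc32)cc1` gives 24200 nM

Compound 3 holds the lowest of the three numbers, but the distances are small: a 1.2-fold lower number from compound 2 to compound 3 (0.08 log units; within the scatter) and a 1.3-fold lower number from compound 1 to compound 3 (0.13 log units; within the scatter), both within the scatter, as is a 1.1-fold lower number from compound 1 to compound 2 (0.05 log units; within the scatter). The three compounds share one core and differ only in the substituent on the aromatic ring that sits on the saturated chain carbon bound to an oxygen on an unsaturated carbon; methyl, fluoro and trifluoromethyl there give numbers that cannot be told apart.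

Compound 4 `Fc1ccc(CO/N=C2/C(c3c[nH]c4ccccc34)=Nc3ccccc32)c(Cl)c1` is not yet measured in this assay. Relative to compound 3 the change is 2-chloro-4-fluorophenyl in place of 4-(trifluoromethyl)phenyl on a saturated chain carbon bound to an oxygen on an unsaturated carbon. All three measured steps bear on it, since each exchanged a substituent on this same ring, and none of them moved the number beyond the scatter. Among the compounds with values here, the exchange to compound 4 again reworks only that ring, with chloro and fluoro in place of trifluoromethyl, and nothing points to a step of a different size. For compound 4 the expected value in this assay is therefore 27000 nM, with a range from 12000 nM to 60000 nM. The step this estimate implies, a 1.1-fold higher number from compound 3 to compound 4 (0.05 log units; within the scatter), is expected to stay within the scatter.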

Compound 4, half-maximal inhibitory concentration: 37600 nM
Beside the measured number, compound 4's estimate is 1.4-fold (0.14 log units) below it, and the stated range covers the measured number.
By their numbers in this assay, from the lowest: compounds 3, 2, 1 and 4 (each within the scatter of the next).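

In this assay, within the data shown here, the ring at this position takes a second substituent for the first time, and the addition of chloro gives a 1.3-fold higher number from compound 2 to compound 4 (0.11 log units; within the scatter), so this added chloro does not separate compound 4 from compound 2. The larger exchanges of the whole ring behave in the same way: the step to 2-chloro-4-fluorophenyl from 4-(trifluoromethyl)phenyl is a 1.6-fold higher number from compound 3 to compound 4 (0.19 log units; within the scatter) and the step from 4-methylphenyl is a 1.2-fold higher number from compound 1 to compound 4 (0.06 log units; within the scatter), which leaves all four compounds indistinguishable in this read-out, with no substituent pattern on the ring that can be ranked. No supporting measurement bears on these numbers, so nothing can be said about the reason for this flat behaviour.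

The compounds shown carry only methyl and halogen-bearing substituents on this ring, so it remains open whether an amine or a carboxylic acid there would produce a step beyond the scatter. Also open, from the compounds shown here alone, is whether a longer chain in place of the saturated chain carbon, or any change to the shared core, would move the number at all.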